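A few compounds are considered here, and "the series" means these few. Any claim that something is new, unique, unknown or untested is made for them only; others in the source may bear on it.

Working notes on the series, read in a functional assay on HT-29 cells (Homo sapiens) for inhibition, read by sulforhodamine B assay, with a stated time of 48 h; a higher number here means a weaker inhibitor of growth, a lower number a stronger inhibitor of growth. Compound 1 (`c1cc2c(cc1NC1=NCCO1)CCC2`) gives 4900 nM. Compound 2 (`O=C(CCl)NC(=O)Nc1ccc(C2CCCCC2)cc1`) gives 2300 nM. Compound 3 (`O=C(CCl)NC(=O)Nc1ccc(OC2CCCC2)cc1`) gives 3100 nM, the second highest of the three numbers and within the scatter of both other compounds.

Next in line is compound 4 (`O=C(CCl)NC(=O)Nc1ccc(Oc2ccccc2)cc1`), not yet measured. The structural change is phenyl in place of cyclopentyl on an oxygen on an aromatic ring. Put simply, cyclopentyloxy gives way to phenoxy.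

For the measured compounds named here, one measured step bears on this site: a 1.3-fold higher number from compound 2 to compound 3 (0.13 log units; within the scatter), with cyclopentyloxy in place of cyclohexyl on an aromatic carbon. That single step shows little movement in this assay when the group at this site is exchanged, but it involves only non-aromatic rings. Going by the values given here, no measured compound carries phenoxy, so the data give no direction for the change. Compound 1 does not share the core of compound 3 and adds nothing to this comparison.

No step beyond the scatter is therefore expected, and the direction is left open. The expected step is a 1.1-fold lower number from compound 3 to compound 4 (0.04 log units; within the scatter). The estimated value for compound 4 is 2800 nM, with an expected range from 1400 nM to 5500 nM.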

Compound 4, concentration for 50% growth inhibition: 3600 nM
Estimate against measurement, compound 4: 1.3-fold (0.11 log units) below; the measured number falls inside the stated range.
By their numbers in this assay, from the lowest: compounds 2, 3, 4 and 1 (each within the scatter of the next, the first and the last beyond it).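

In this assay, exchanging the non-aromatic ring on the oxygen for an aromatic one gives a 1.2-fold higher number from compound 3 to compound 4 (0.06 log units; within the scatter), so the earlier reading of little movement at this site now extends beyond non-aromatic rings. Set against the cyclohexyl group, phenoxy gives a 1.6-fold higher number from compound 2 to compound 4 (0.19 log units; within the scatter), which leaves cyclohexyl, cyclopentyloxy and phenoxy unseparated in this read-out, with neither the ring type nor the oxygen link producing a step beyond the scatter. No supporting measurement is available to explain why these values sit together.

As far as these compounds go, all three groups at this site are carbon rings, attached directly or through an oxygen, so it remains open whether an amine, a carboxylic acid or a longer alkyl chain in their place would give a step beyond the scatter. The compounds also leave open what a change elsewhere on the shared core would do, such as a methyl group in place of the chlorine.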